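The source may hold more compounds than are shown below. What is called first, only, known or untested is meant among the compounds shown, and "the series" means these compounds.

Compound 1 `CCCCCCCCCCCCCC(=O)OCCc1ccc(O)c(O)c1`: > 50000 nM
Compound 2 `CCCCCCCCCC(=O)OCCc1ccc(O)cc1`: 172000 nM

Both compounds were tested in a toxicity assay on MRC5 cells (Homo sapiens) for inhibition, read by MTT assay, with a stated time of 72 h; on this read-out higher numbers stand for weaker inhibition and lower numbers for stronger inhibition. Compound 1 stands at > 50000 nM, which is a limit of the assay and not a number. Compound 3 `CCCCCCCCCCCC(=O)OCCc1ccc(O)c(O)c1` differs from compound 1 by hydrogen in place of ethyl on a saturated chain carbon, ten or more bonds along the chain from a carbonyl carbon. Within the data shown here, no measured step shows what such a change does in this assay, so no shift beyond the scatter is expected, and no firm direction. Among the measured compounds shown here, the only true number, for compound 2, is 172000 nM, and the expectation leans on it. The estimated change is a step that the limit leaves unreadable from compound 1 to compound 3. For compound 3 the expected value is 80000 nM, with an estimated range of 30000 nM to 200000 nM.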

Compound 3, half-maximal inhibitory concentration: 38100 nM
Estimate against measurement, compound 3: 2.1-fold (0.32 log units) above; the measured number falls inside the stated range.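

In this assay, hydrogen in place of ethyl on a saturated chain carbon, ten or more bonds along the chain from a carbonyl carbon, gives an at least 1.3-fold lower number from compound 1 to compound 3 (0.11 log units; that floor lies within the scatter). Compound 3 thus gives this chain a true number, 38100 nM. The value of compound 1 is a limit, so the step has only a floor: the limit of > 50000 nM in this assay, at which 1 of the 3 values shown sits.

On these data alone, the true size of the step remains open. So does whether a longer chain or an amine at this place would move the number beyond the scatter.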